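Swapping Cyclobutyl for Phenyl on a Sulfonamide Side Chain

This account rests on a few compounds, and the source may have more. Where it says the series, first, only, none or still open, it means among the compounds named here.

Compound 1 `CCc1ccc(N(C2COC2)S(=O)(=O)c2ccc3c(c2)C(O)CC(C2CCOCC2)O3)cc1`: 2.63
Compound 2 `CCc1ccc(N(CC(C)C)S(=O)(=O)c2ccc3c(c2)C(O)CC(C2CCOCC2)O3)cc1`: 4.12
Compound 3 `CCc1ccc(N(CC2CCC2)S(=O)(=O)c2ccc3c(c2)C(O)CC(C2CCOCC2)O3)cc1`: 4.01

In a physicochemical assay for lipophilicity, at pH 7.4 (a higher number here means a more lipophilic compound, a lower number a more polar compound), compound 3 gives 4.01, which places it level with compound 2 at the top of the three numbers and well away from compound 1. Compound 4 `CCc1ccc(N(Cc2ccccc2)S(=O)(=O)c2ccc3c(c2)C(O)CC(C2CCOCC2)O3)cc1` has not yet been measured. It differs from compound 3 by phenyl in place of cyclobutyl on a saturated chain carbon bound to a sulfonamide nitrogen.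

Within the data shown here, the closest precedent changes the same place, and there the value moved only slightly, with a number 0.11 log units lower from compound 2 to compound 3 (within the scatter). The two large steps, a number 1.49 log units higher from compound 1 to compound 2 (beyond the scatter) and a number 1.38 log units higher from compound 1 to compound 3 (beyond the scatter), both start from oxetan-3-yl. Compound 4 has no such group, so these steps bear on the change only weakly. No step beyond the scatter is therefore expected in this assay. The estimate means an expected a number 0.06 log units lower from compound 3 to compound 4 (within the scatter). Compound 4 is expected at 3.95, within an estimated range from 3.6 to 4.3.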

Compound 4, distribution coefficient: 4.68
Estimate against measurement, compound 4: 0.73 log units below; measured number outside the range, above it.
By their numbers in this assay, from the lowest: compound 1; then compounds 3 and 2 (each within the scatter of the next); then compound 4.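

At this place on a saturated chain carbon bound to a sulfonamide nitrogen, this assay had not separated isobutyl from cyclobutylmethyl, but the benzyl of compound 4 stands apart from both, with a number 0.67 log units higher from compound 3 to compound 4 (beyond the scatter) and a number 0.56 log units higher from compound 2 to compound 4 (beyond the scatter). So this position is not indifferent to every carbon-only group, and compound 4 now holds the highest number of the four, with the distance from the oxetan-3-yl compound widened to a number 2.05 log units higher from compound 1 to compound 4 (beyond the scatter). Nothing measured here explains why phenyl and cyclobutyl part at this place.

The compounds shown leave open whether the rise follows the six-membered aromatic ring itself or its larger carbon count, which a cyclohexyl group in the same place would separate. They also leave open how a pyridyl ring or the longer phenethyl chain would read in this assay.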